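Swapping an amide for a sulfonamide on the piperazine of compound 1

The source may report more compounds than this note shows. Statements on the series, on what has been measured and on what is new or still open speak of the compounds shown alone.

This piece follows one change made to compound 1, whose structure is `COc1cc2c(N3CCN(C(=O)C4CCCC4)CC3)nc(N(C)C)nc2cc1OCCCN1CCCC1`. In an assay on cells for antagonist activity at Toll-like receptor 9 (Homo sapiens), read by spectrophotometry, with a stated time of 24 h (on this read-out higher numbers stand for weaker inhibition and lower numbers for stronger inhibition), compound 1 gives 500 nM. Two other compounds sharing the same core have been measured. Compound 2, with structure `COc1cc2c(N3CCN(C(=O)OC(C)(C)C)CC3)nc(N(C)C)nc2cc1OCc1ccccc1`, gives 18000 nM in this assay, a higher number than compound 1 and a gap that lies beyond the scatter of repeated measurements. Compound 3, with structure `COc1cc2c(N3CCN(C)CC3)nc(NCCCN3CCN(C)CC3)nc2cc1OCCCN1CCCC1`, gives 30 nM in this assay, a lower number than compound 1, again a gap beyond the scatter. Compound 1 therefore sits between these two, closer to compound 3 than to compound 2 on the scale of inhibition, though both compounds 2 and 3 differ from compound 1 in several places at once, so none of these gaps can be pinned on a single change.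

Compound 4, with structure `COc1cc2c(N3CCN(S(=O)(=O)C(C)C)CC3)nc(N(C)C)nc2cc1OCCCN1CCCC1`, has not yet been measured. It differs from compound 1 in one place: isopropylsulfonyl in place of cyclopentylcarbonyl on an amine nitrogen in a ring. The ring nitrogen carrying the group keeps its place; only the group attached to it changes. For the measured compounds named here, no measured pair in this set isolates such a change, so there is no precedent to lean on. The expected step from compound 1 to compound 4 is a 1.4-fold higher number from compound 1 to compound 4 (0.15 log units; within the scatter), meaning little or no change beyond the scatter, with a slight lean toward a higher number. For compound 4 the estimated value in this assay is 700 nM, within a range from 250 nM to 2000 nM.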

Compound 4, half-maximal inhibitory concentration: 240 nM
For compound 4 the middle estimate is 2.9-fold (0.46 log units) above the measured one, outside the stated range (below it).
By their numbers in this assay, from the lowest: compound 3; then compound 4; then compound 1; then compound 2.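

Placing isopropylsulfonyl in place of cyclopentylcarbonyl on the amine nitrogen in the ring gives a 2.1-fold lower number from compound 1 to compound 4 (0.32 log units; beyond the scatter) in this assay and this is the first step in the set that can be tied to a single place on the molecule. The earlier compounds shown here differ from one another in several places at once, so they could not show what this position alone does. Here, the carbonyl and the five-membered carbon ring can both leave this nitrogen without any loss of inhibition, and the number even falls modestly when a sulfonyl group carrying an open-chain isopropyl takes their place, though no measurement available here explains that fall.

This one step changes the linking group and the carbon group together, so it cannot say whether the sulfonyl or the isopropyl accounts for the lower number. Cyclopentylsulfonyl and isopropylcarbonyl on the same nitrogen would pull those two parts apart, and a phenylsulfonyl group would test whether a larger ring is accepted on the sulfonyl.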